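Working notes on the shared core: compound 4 expected

The source may report more compounds than this note shows. Statements on the series, on what has been measured and on what is new or still open speak of the compounds shown alone.

Measured so far in a functional assay on MCF7 cells (Homo sapiens) for cytotoxicity, read by MTT assay, with a stated time of 48 h; on this read-out lower numbers stand for stronger inhibition and higher numbers for weaker inhibition:
compound 1 `Fc1cccc(-c2nc(Nc3ccccc3F)c3cc(F)ccc3n2)c1` — compound 1 gives > 50000 nM, a limit of the assay.
compound 2 `Fc1cccc(-c2nc(Nc3cccc(Cl)c3)c3cc(F)ccc3n2)c1` — compound 2 gives > 50000 nM, a limit of the assay.
compound 3 `Oc1ccc(Nc2nc(-c3cccc(F)c3)nc3ccc(F)cc23)cc1` — compound 3 gives > 50000 nM, a limit of the assay.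

Compound 2 therefore stands at a limit only, with no number, and the other two values are limits as well (the limit of > 50000 nM in this assay, at which 3 of the 3 values shown sit). The steps a step that the two limits leave unreadable from compound 1 to compound 2, a step that the two limits leave unreadable from compound 1 to compound 3 and a step that the two limits leave unreadable from compound 2 to compound 3 give no readable size in this assay.

Compound 4 `Cc1ccccc1Nc1nc(-c2cccc(F)c2)nc2ccc(F)cc12` differs from compound 2 by 2-methylphenyl in place of 3-chlorophenyl on a nitrogen on an aromatic ring. Among the measured compounds shown here, no measured step bears on this change, so no direction can be expected beyond a further limit. The step from compound 2 to compound 4 is expected as a step that the limit leaves unreadable from compound 2 to compound 4. Compound 4 is expected at 60000 nM, between 20000 nM and 200000 nM.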

Compound 4, half-maximal inhibitory concentration: > 50000 nM
Compound 4: a limit, no number; the forecaster's own chance of this, stated with the estimate: 75%; the middle value does not contradict the limit.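

In this assay, among the compounds shown here, compound 4 gives > 50000 nM as a limit of the assay and not a number, so no step linking it to compound 1, compound 2 or compound 3 can be read. The compounds shown leave open whether any group on the nitrogen changes the read-out in this series.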